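A few compounds are considered here, and "the series" means these few. Any claim that something is new, unique, unknown or untested is made for them only; others in the source may bear on it.

Working notes on a small set of purine-type compounds carrying a chloromethylbenzyl group. Compound 1 `ClCc1cccc(Cn2cnc3c(Cl)nc(Cl)nc32)c1` has no result in a functional assay on SK-OV-3 cells (Homo sapiens) for cytotoxicity, read by sulforhodamine B assay, with a stated time of 48 h; a higher number here means that more compound is tolerated, a lower number that less compound is tolerated; its entry reads "not determined" (no result reported). Compound 2 `Nc1nc(Cl)c2ncn(Cc3ccccc3CCl)c2n1` returns only a limit in this assay, > 100000 nM, so it is one of the entries that sit at the limit of > 100000 nM in this assay, at which 1 of the 3 values shown sits, and no single number is available for it. Compound 3 `ClCc1ccccc1Cn1cnc2ncnc(Cl)c21`, which bears the chloro group on the other side of the core, gives 85100 nM in this assay. Compound 4 `ClCc1ccccc1Cn1cnc2c(Cl)ncnc21` differs from compound 2 by hydrogen in place of amino on an aromatic carbon. Among the compounds with values here, no step between measured compounds exists to calibrate this change; the expected step from compound 2 to compound 4 is a number no higher from compound 2 to compound 4 (the limit leaves the size open), not beyond the scatter. Compound 4 is therefore estimated at 100000 nM, within 50000 nM to 200000 nM.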

Compound 4, concentration lethal to 50% of the cells: 85100 nM
Beside the measured number, compound 4's estimate is 1.2-fold (0.07 log units) above it; the range from low to high includes it.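

In this assay hydrogen in place of amino on an aromatic carbon between two ring nitrogen atoms gives an at least 1.1-fold lower number from compound 2 to compound 4 (0.07 log units; that floor lies within the scatter) at this position. Within the data shown here, this is the first step that can be read, and it has a direction only: losing the amino group does not raise the number, yet nothing yet shows a change beyond the scatter.

From the compounds shown here alone, whether a methylamino group or a methoxy group on this carbon would shift the number stays open. The full size of the amino step also stays open, as compound 2 holds a limit and not a number: the limit of > 100000 nM in this assay, at which 1 of the 4 values shown sits.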